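The source may report more compounds than this note shows. Statements on the series, on what has been measured and on what is new or still open speak of the compounds shown alone.

Compound 3 `CC(=O)Nc1ccc2oc(-c3ccc(C(F)(F)F)cc3)cc(=O)c2c1` gives 330000 nM in an ADME assay on MT4 cells (Homo sapiens) for cytotoxicity, read by MTT assay, with a stated time of 4 days (on this read-out higher numbers stand for lower toxicity in this test and lower numbers for higher toxicity in this test), the top of the three numbers in hand, though the other two sit within the scatter of it: compound 1 `COc1ccc(-c2cc(=O)c3cc(NC(C)=O)ccc3o2)cc1` gives 226000 nM and compound 2 `CC(=O)Nc1ccc2oc(-c3ccc(F)cc3)cc(=O)c2c1` gives 203000 nM. The step of a 1.5-fold higher number from compound 1 to compound 3 (0.16 log units; within the scatter) and the step of a 1.6-fold higher number from compound 2 to compound 3 (0.21 log units; within the scatter) are both small, as is the step of a 1.1-fold lower number from compound 1 to compound 2 (0.05 log units; within the scatter); none of the three substitutions on the pendant aromatic ring moved this read-out beyond the scatter.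

Compound 4 `CC(=O)Nc1ccc2oc(-c3ccc(C(F)(F)F)cc3)c(O)c(=O)c2c1` differs from compound 3 by hydroxy in place of hydrogen on an aromatic carbon. Among the measured compounds shown here, no measured step touches this position or this kind of change; the only steps available concern the pendant aromatic ring, and all of them stayed within the scatter. With nothing in the measured steps pointing either way, compound 4 is expected to stay close to compound 3 in this assay, with the step of a 1.2-fold lower number from compound 3 to compound 4 (0.07 log units; within the scatter) expected to fall within the scatter. Compound 4 is therefore estimated at 280000 nM, with a range from 110000 nM to 600000 nM.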

Compound 4, half-maximal cytotoxic concentration: 7300 nM
For compound 4 the middle estimate is 38-fold (1.58 log units) above the measured one; measured number below the stated range.
By their numbers in this assay, from the lowest: compound 4; then compounds 2, 1 and 3 (each within the scatter of the next).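

In this assay, hydroxy in place of hydrogen on the aromatic carbon two atoms from the ring oxygen gives a 45-fold lower number from compound 3 to compound 4 (1.66 log units; beyond the scatter), a clear move towards higher toxicity in this test. The earlier steps, all on the pendant aromatic ring, stayed within the scatter, so this carbon is the first place among the compounds shown where a single change moves the read-out beyond it. Nothing available here accounts for the size of this step.

The compounds shown leave open whether the shift belongs to hydroxy itself or would also follow from another group on this carbon, such as an amine, a methyl group or a fluorine atom. They also leave open whether hydroxy here would have the same effect with methoxy or fluoro on the pendant ring in place of trifluoromethyl.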